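The source may hold more compounds than are shown below. What is called first, only, known or untested is meant among the compounds shown, and "the series" means these compounds.

Working notes on the series. Compound 1 `COc1ccc(/C=N/NC(=O)c2cc(-c3ccc(Cl)cc3)nn2Cc2ccc(Cl)nc2)cc1` went into a physicochemical assay on A549 cells for solubility, read by microscopy, with a stated time of 24 h (a lower number here means a stronger inhibitor, a higher number a weaker inhibitor), but returned no result: compound 1 stands there as "not determined" (no result reported), so it contributes no number. Compound 2 `COc1ccc(-c2cc(C(=O)N/N=C/c3ccccc3O)n(Cc3ccc(Cl)nc3)n2)cc1` is therefore the only entry in this assay with a figure: compound 2 gives 570 nM, and it stands alone, with nothing measured to set it against. Among the compounds with values here, no step between two measured compounds exists here, so the scatter of the method is the only yardstick for what follows.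

Compound 3 `COc1ccc(/C=N/NC(=O)c2cc(-c3ccc(OC)cc3)nn2Cc2ccc(Cl)nc2)cc1` is the next one to be measured in this assay. Against compound 2 it shows one change, (4-methoxyphenyl in place of 2-hydroxyphenyl on a carbon with a double bond to nitrogen), in words: 4-methoxyphenyl in place of 2-hydroxyphenyl on a carbon with a double bond to nitrogen. Within the data shown here, with a single measured number and no measured step, the size of the move this change brings in this assay cannot be read from the series; the working expectation is a step not beyond the usual scatter, in no set direction, written as a 1.2-fold higher number from compound 2 to compound 3 (0.09 log units; within the scatter). On that basis compound 3 is estimated at 700 nM in this assay, with a range from 250 nM to 2000 nM, the width reflecting that the expectation rests on one value only.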

Compound 3, half-maximal inhibitory concentration: 18900 nM
Estimate against measurement, compound 3: 27-fold (1.43 log units) below; measured number outside the range, above it.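

In this assay, within the data shown here, the group on the carbon with a double bond to nitrogen proves able to move the number strongly: 4-methoxyphenyl in place of 2-hydroxyphenyl gives a 33-fold higher number from compound 2 to compound 3 (1.52 log units; beyond the scatter), the first step with a readable size and a large one. In this pair, the compound carrying 2-hydroxyphenyl is the stronger inhibitor, so this position cannot be treated as indifferent to the change. The swap alters more than one feature at once, with 1 hydrogen-bond donor leaving and 0 entering and 7 heavy atoms giving way to 8, and nothing available bears on which of these features goes with the step.

Steps involving compound 1 cannot be read, so this single pair gives no view of how the change behaves on any other version of the core. Going by these compounds, it also remains open how a plain phenyl or an aminophenyl group at this position would compare, and whether the number follows the hydroxyl group itself or the whole aryl group that carries it.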